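This account rests on a few compounds, and the source may have more. Where it says the series, first, only, none or still open, it means among the compounds named here.

Measured so far in a functional assay on SK-OV-3 cells (Homo sapiens) for antiproliferative activity, read by MTT assay, with a stated time of 72 h; on this read-out lower numbers stand for stronger inhibition and higher numbers for weaker inhibition:
- compound 1 `O=C(CCc1cccc2c1B(O)OC2)NC1CCCCC1`: > 100000 nM (a limit)
- compound 2 `O=C(CCc1cccc2c1B(O)OC2)Nc1ccc(Cl)cc1`: 5000 nM
- compound 3 `O=C(CCc1cccc2c1B(O)OC2)Nc1cccc(I)c1`: 630 nM

Compound 3, at 630 nM, has the lowest number of the three, and its steps to both others lie beyond the scatter. Next is compound 4 `O=C(CCc1cccc2c1B(O)OC2)Nc1cccc(-c2cccc(F)c2)c1`, where 3-fluorophenyl stands in place of iodo on an aromatic carbon, meta to a large group: 3-fluorophenyl in place of iodo on an aromatic carbon.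

Among the measured compounds shown here, no measured step makes this exact replacement. The nearest evidence comes from changes to the group on the amide nitrogen: an at least 20-fold lower number from compound 1 to compound 2 (1.30 log units; beyond the scatter), an at least 150-fold lower number from compound 1 to compound 3 (2.20 log units; beyond the scatter) and a 7.9-fold lower number from compound 2 to compound 3 (0.90 log units; beyond the scatter). The last is the closest in kind, being modest and between two halogenated phenyl groups. The two large steps start from cyclohexyl, so they carry less weight here. On the strength of a 7.9-fold lower number from compound 2 to compound 3 (0.90 log units; beyond the scatter), a modest shift towards a lower number is expected, with a wide margin. The expected change is a 2.5-fold lower number from compound 3 to compound 4 (0.40 log units; beyond the scatter). For compound 4 the estimate is 250 nM, with an expected range of 40 nM to 1500 nM.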

Compound 4, half-maximal inhibitory concentration: 480 nM
Compound 4: the middle estimate sits 1.9-fold (0.28 log units) below what was measured; low and high end bracket the measured number.
By their numbers in this assay, from the lowest: compounds 4 and 3 (each within the scatter of the next); then compound 2. At a limit, above all of these: compound 1.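

In this assay the swap of iodo for 3-fluorophenyl gives a 1.3-fold lower number from compound 3 to compound 4 (0.12 log units; within the scatter) and so stays within the scatter: this aromatic carbon, meta to a large group, takes a group of 7 heavy atoms carrying a six-membered aromatic ring in place of a single iodine with no clear change in the number. The earlier compounds shown here differ only in the whole group on the amide-type nitrogen, and they gave no reading of a substituent change at this carbon. Nothing at hand bears on why iodo and 3-fluorophenyl read alike here.

Open, going by these compounds, is how an amine, a carboxylic acid or an unsubstituted phenyl would read at this carbon. The core is shared by all the compounds shown, so the effect of a longer chain to the amide carbonyl also remains open.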